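The source may hold more compounds than are shown below. What is called first, only, known or untested is meant among the compounds shown, and "the series" means these compounds.

Going by the values given here, compound 2 `Cc1cc(C(=O)O)nn1Cc1cc(Br)ccc1OCc1ccc(Cl)cc1Cl` gives the lower of the two numbers measured so far in a functional assay on CHO-K1 cells for antagonist activity at prostaglandin E2 receptor EP1 subtype (Homo sapiens), read by FLIPR (a lower number here means a stronger inhibitor, a higher number a weaker inhibitor), namely 0.49 nM. Among the compounds with values here, its only measured neighbour is compound 1 `Cc1cc(C(=O)O)nn1Cc1cc(Br)ccc1OCc1ccccc1`, which in this assay gives 15.1 nM. Within the data shown here, the single measured step between them, a 31-fold lower number from compound 1 to compound 2 (1.49 log units; beyond the scatter), shows how strongly the group on the saturated chain carbon bound to an oxygen on an aromatic ring can move the result. Compound 3 `Cc1cc(C(=O)O)nn1Cc1cc(Br)ccc1OCc1ccc(F)cc1F` has not yet been measured; it differs from compound 2 by the change (2,4-difluorophenyl in place of 2,4-dichlorophenyl on a saturated chain carbon bound to an oxygen on an aromatic ring). Among the measured compounds shown here, only the step from compound 1 to compound 2 bears on this question, and it was large; the new change keeps a twice-substituted ring in the same place but trades one pair of halogens for another, so a smaller step than that one is expected, with compound 3 expected to give back part of what compound 2 gained over compound 1. The step expected in this assay is a 6.1-fold higher number from compound 2 to compound 3 (0.79 log units; beyond the scatter), toward a higher number. Compound 3 is therefore estimated at 3 nM in this assay, with a range from 0.8 nM to 12 nM.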

Compound 3, inhibition constant: 2.63 nM
Compound 3: middle estimate off by 1.1-fold (0.06 log units), on the high side; measured number inside the range.
By their numbers in this assay, from the lowest: compound 2; then compound 3; then compound 1.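

Changing 2,4-dichlorophenyl to 2,4-difluorophenyl on the saturated chain carbon gives a 5.4-fold higher number from compound 2 to compound 3 (0.73 log units; beyond the scatter) in this assay, so at this position the identity of the halogens matters, not only the pattern in which they sit on the ring. Compound 3 still keeps part of the gain over the plain phenyl ring, with a 5.7-fold lower number from compound 1 to compound 3 (0.76 log units; beyond the scatter), which places both twice-halogenated rings ahead of phenyl in these three compounds, with the 2,4-dichlorophenyl ring furthest ahead. Nothing shown here explains why the chlorine pair and the fluorine pair give different numbers.

The three rings shown change both halogens together, so they cannot tell how much each of the two ring positions adds alone, a question that a 4-chlorophenyl or a 2-chlorophenyl ring could help to answer. It also remains open whether halogens are needed at all, as a 2,4-dimethylphenyl or a 2,4-dimethoxyphenyl ring in the same place could show whether the trend among these three compounds extends to groups of another kind.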